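The source may report more compounds than this note shows. Statements on the series, on what has been measured and on what is new or still open speak of the compounds shown alone.

Measured compounds:
compound 1 `O=C(N/N=C/c1ccc(O)cc1)c1cccnc1Nc1cccc(C(F)(F)F)c1` gives 68%
compound 2 `COc1cccc(/C=N/NC(=O)c2cccnc2Nc2cccc(C(F)(F)F)c2)c1` gives 49.7%

Both were tested in a functional assay on the whole organism (strain Wistar) for inhibition, with Rattus norvegicus as the target, read by paw edema, with a stated time of 2 h, at a dose of 10 mg/kg by the intraperitoneal route; on this read-out lower numbers stand for less inhibition and higher numbers for more inhibition at the one dose given (going by the name of the read-out). Among the compounds with values here, compound 2 stands lowest of the two numbers; the only measured step, a number 18.3 percentage points lower from compound 1 to compound 2 (beyond the scatter), separates it from compound 1.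

Compound 3 `COc1ccc(/C=N/NC(=O)c2cccnc2Nc2cccc(C(F)(F)F)c2)cc1` differs from compound 2 by 4-methoxyphenyl in place of 3-methoxyphenyl on a carbon with a double bond to nitrogen. Within the data shown here, only that measured step bears on this change, and it altered both the group and its position, so it is an imperfect guide. Because compound 1 gives 68% with its group in the same position that compound 3 now has, a modest rise is expected. Compound 3 is estimated at 58%, ranging from 45% to 70%. The expected step is a number 8.3 percentage points higher from compound 2 to compound 3 (within the scatter).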

Compound 3, a percentage reported as inhibition, in the whole organism at one dose (the size of the read-out at that dose, not a potency): 42.4%
Compound 3: the middle estimate sits 15.6 percentage points above what was measured; measured number outside the range, below it.
By their numbers in this assay, from the lowest: compounds 3 and 2 (each within the scatter of the next); then compound 1.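

In this assay, 4-methoxyphenyl in place of 3-methoxyphenyl gives a number 7.3 percentage points lower from compound 2 to compound 3 (within the scatter), so these two placings of the methoxy group cannot be told apart here. Within the data shown here, the methyl on the oxygen of the aromatic ring, the only change at this one position, gives a number 25.6 percentage points lower from compound 1 to compound 3 (beyond the scatter), so the free hydroxyl of compound 1 is linked to the higher number. No measurement shown explains this difference. The compounds shown leave open whether an amine or a carboxylic acid on the aromatic ring would match the hydroxyl, and whether a longer chain on the oxygen would lower the number further.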